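This account rests on a few compounds, and the source may have more. Where it says the series, first, only, none or still open, it means among the compounds named here.

In a physicochemical assay for lipophilicity, using the shake flask method, measured as octanol-water partition, at pH 7.4 (a higher number here means a more lipophilic compound, a lower number a more polar compound), compound 3 (`CC(=O)N[C@@H]1CCC[C@H](C(=O)Nc2cc(-c3nnn4ccccc34)c(Cl)cn2)C1`) gives 2 and sits within the scatter of compound 1 (`CC(=O)N[C@@H]1CCC[C@H](C(=O)Nc2cc(-c3cnc(C)n3C(C)C)ccn2)C1`) at 1.9 while compound 2 (`CC(=O)N[C@@H]1CCC[C@H](C(=O)Nc2cc(-c3cnn4c3CCCC4)c(Cl)cn2)C1`) stands clearly higher at 3.2 on the same scale. Compound 4 (`CC(=O)N[C@@H]1CCC[C@H](C(=O)Nc2cc(-c3cnn4c3NCCC4)c(Cl)cn2)C1`) follows from compound 3 by one change (a group of 9 heavy atoms (6 carbon, 3 nitrogen; one five-membered aromatic ring with 2 hetero atoms, one six-membered non-aromatic ring with 2 hetero atoms) in place of a group of 9 heavy atoms (6 carbon, 3 nitrogen; one five-membered aromatic ring with 3 hetero atoms, one six-membered aromatic ring with 1 hetero atom), on an aromatic carbon). Among the measured compounds shown here, one measured step bears on it (a number 1.20 log units lower from compound 2 to compound 3 (beyond the scatter)), a large one that ran the other way in ring types. Compound 4 returns to the ring types of compound 2 (3.2) but has a six-membered non-aromatic ring with 2 hetero atoms, so in this assay only a partial return upward is expected. The expected step is moderate (a number 0.50 log units higher from compound 3 to compound 4 (beyond the scatter)). Compound 4 is estimated at 2.5 within an expected range (2 to 3).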

Compound 4, distribution coefficient: 2.4
Compound 4: middle estimate off by 0.10 log units, on the high side; low and high end bracket the measured number.
By their numbers in this assay, from the lowest: compounds 1 and 3 (each within the scatter of the next); then compound 4; then compound 2.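

In this assay, two steps now bracket the group on this aromatic carbon, ortho to a chloro group: a number 0.40 log units higher from compound 3 to compound 4 (beyond the scatter), and a number 0.80 log units lower from compound 2 to compound 4 (beyond the scatter). Compound 2 and compound 4 share the five-membered aromatic ring with 2 hetero atoms, so a second hetero atom in the six-membered non-aromatic ring, which brings 1 hydrogen-bond donor, is enough for a step beyond the scatter. Nothing available explains the size of either step.

Going by these compounds, whether that ring position needs its hydrogen remains open. A methyl group on that ring nitrogen, or an ether oxygen in its place, would address this.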